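Thiobenzyl replacement by cyclopropylmethyl in a triazolopyrimidine series

The source may report more compounds than this note shows. Statements on the series, on what has been measured and on what is new or still open speak of the compounds shown alone.

Measured compounds and their values in a functional assay on MCF7 cells (Homo sapiens) for inhibition, read by MTT assay, with a stated time of 72 h; on this read-out higher numbers stand for weaker inhibition and lower numbers for stronger inhibition:
- compound 1, `Cc1cc(Nc2cc(-c3ccccc3)[nH]n2)n2nc(SCc3c(Cl)cccc3Cl)nc2n1`: 3230 nM
- compound 2, `Cc1cc(Nc2cc(-c3ccccc3)[nH]n2)n2nc(SCc3ccc(Cl)cc3)nc2n1`: 8260 nM
- compound 3, `Cc1ccc(CSc2nc3nc(C)cc(Nc4cc(-c5ccccc5)[nH]n4)n3n2)cc1`: 7290 nM

Compound 1 gives the lowest number of the three. Its steps to the other two are both beyond the scatter: a 2.6-fold higher number from compound 1 to compound 2 (0.41 log units; beyond the scatter) and a 2.3-fold higher number from compound 1 to compound 3 (0.35 log units; beyond the scatter). Between compound 2 and compound 3 the change is a 1.1-fold lower number from compound 2 to compound 3 (0.05 log units; within the scatter), so these two cannot be ordered.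

Compound 4, `Cc1cc(Nc2cc(-c3ccccc3)[nH]n2)n2nc(SCC3CC3)nc2n1`, is not yet measured. It differs from compound 1 as follows: cyclopropyl in place of 2,6-dichlorophenyl on a saturated chain carbon bound to a sulfur.

Both measured steps that bear on this change start from compound 1 and exchange the 2,6-dichlorophenyl on the saturated chain carbon bound to a sulfur for another group; each gave a modest rise in the number. Compound 4 goes further, taking the aromatic ring away altogether and putting in a cyclopropyl. Going by the values given here, no measured compound shows what this does, so the expectation leans on the two modest steps and allows a wider spread. A rise in this assay is expected, of about a 2.8-fold higher number from compound 1 to compound 4 (0.45 log units; beyond the scatter).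

Compound 4 is therefore estimated at 9000 nM, within a range from 3500 nM to 25000 nM.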

Compound 4, half-maximal inhibitory concentration: > 50000 nM
Compound 4: only a limit was reported (the forecaster's own chance of this, stated with the estimate: 15%); middle value at least 5.5-fold (0.74 log units) away from the limit.
By their numbers in this assay, from the lowest: compound 1; then compounds 3 and 2 (each within the scatter of the next). At a limit, above all of these: compound 4.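

In this assay compound 4 gives only a limit and not a number: the limit of > 50000 nM in this assay, at which 1 of the 4 values shown sits.

Among the earlier compounds, exchanging one substituted phenyl for another on the saturated chain carbon bound to a sulfur produced only modest steps, whereas cyclopropyl opens a far wider gap, with an at least 15-fold higher number from compound 1 to compound 4 (1.18 log units; beyond the scatter) as the large step and an at least 6.8-fold higher number from compound 3 to compound 4 (0.83 log units; beyond the scatter) and an at least 6.0-fold higher number from compound 2 to compound 4 (0.78 log units; beyond the scatter) as the two smaller readable ones. The series therefore tolerates changes of substituent on this phenyl much better than the exchange of the phenyl for cyclopropyl, and compound 4 is the only one of the four without an aromatic ring at this position.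

The change removes the aromatic ring and also reduces the group from 8 heavy atoms to 3, so the compounds shown cannot separate these two differences. From the compounds shown here alone, a cyclohexyl group, which is saturated but larger, and an unsubstituted phenyl or a longer alkyl chain at the same place would help to tell them apart, while a basic amine or a carboxylic acid there remains unexplored.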